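Extending the amine chain of compound 2

The compounds below may be only part of what the source reports. "The series", "measured", "known", "first", "only" and "open" are said of these compounds alone.

Measured in a functional assay on EJ cells (Homo sapiens) for cytotoxicity, read by MTT assay, with a stated time of 48 h; a lower number here means a stronger inhibitor, a higher number a weaker inhibitor:
Compound 1 `CC(C)=CCC/C(C)=C/CC/C(C)=C/CSc1ccccc1C(=O)NCCN`: > 50000 nM (a limit)
Compound 2 `CC(C)=CCC/C(C)=C/CC/C(C)=C/CSc1ccccc1C(=O)NCCCCN`: 13100 nM

Among the measured compounds shown here, compound 2 holds the only actual number in this assay, as the entry for compound 1 is a limit. Compound 3 `CC(C)=CCC/C(C)=C/CC/C(C)=C/CSc1ccccc1C(=O)NCCCCCN` differs from compound 2 by aminomethyl in place of amino on a saturated chain carbon, four bonds along the chain from an amide-type nitrogen. For the measured compounds named here, the single measured step bearing on this is an at least 3.8-fold lower number from compound 1 to compound 2 (0.58 log units; beyond the scatter), which also lengthened the chain. A smaller step towards a lower number, near the scatter, is expected: a 1.7-fold lower number from compound 2 to compound 3 (0.24 log units; within the scatter). The estimate for compound 3 is 7500 nM, with an expected range of 3000 nM to 19000 nM.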

Compound 3, half-maximal inhibitory concentration: 9850 nM
The estimate for compound 3 lay 1.3-fold (0.12 log units) below the measured number; low and high end bracket the measured number.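

In this assay, aminomethyl in place of amino on this chain carbon gave a 1.3-fold lower number from compound 2 to compound 3 (0.12 log units; within the scatter), so this further lengthening produced no change that can be separated from the scatter, unlike the earlier step. On these data alone, the full lengthening stands as an at least 5.0-fold lower number from compound 1 to compound 3 (0.70 log units; beyond the scatter), and that step rests on a limit, so its true size is unknown: the limit of > 50000 nM in this assay, at which 1 of the 3 values shown sits. As far as these compounds go, whether a still longer chain would bring a clear change remains open. So does the effect of a tertiary amine or a carboxylic acid at the chain end.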